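Second chloro on the aryl of compound 3

A few compounds are considered here, and "the series" means these few. Any claim that something is new, unique, unknown or untested is made for them only; others in the source may bear on it.

Compound 3 `C=CCn1c(=O)/c(=C\c2ccccc2Cl)[nH]c(=O)/c1=C\c1ccccc1OC` gives 700 nM in a functional assay on U-937 cells (Homo sapiens) for cytotoxicity, read by CCK-8 assay, with a stated time of 72 h (on this read-out lower numbers stand for stronger inhibition and higher numbers for weaker inhibition), the lower of the two numbers available, though only by a margin within the scatter. Compound 1 `C=CCn1c(=O)/c(=C\c2cccc(Cl)c2)[nH]c(=O)/c1=C\c1ccccc1OC` gives 1200 nM; the step of a 1.7-fold lower number from compound 1 to compound 3 (0.23 log units; within the scatter). Compound 2 `COc1ccccc1/C=c1/[nH]c(=O)/c(=C\c2cccc(Cl)c2Cl)[nH]c1=O` gives "not active" (no number reported) in this assay and so contributes no number. Compound 4 `C=CCn1c(=O)/c(=C\c2cccc(Cl)c2Cl)[nH]c(=O)/c1=C\c1ccccc1OC` differs from compound 3 by chloro in place of hydrogen on an aromatic carbon. Going by the values given here, no measured step bears directly on this change: compound 2 carries the same 2,3-dichlorophenyl on a different core and differs from compound 1 in two places, so its lack of a number stands alone as a caution. Compound 4 is therefore expected near 1000 nM, between 300 nM and 4000 nM, with a real chance of no number at all. The expected step is a 1.4-fold higher number from compound 3 to compound 4 (0.15 log units; within the scatter), not beyond the scatter.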

Compound 4, half-maximal inhibitory concentration: 500 nM
Estimate against measurement, compound 4: 2.0-fold (0.30 log units) above, within the range that was stated.
By their numbers in this assay, from the lowest: compounds 4, 3 and 1 (each within the scatter of the next, the first and the last beyond it).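

In this assay the change to 2,3-dichlorophenyl gives a 1.4-fold lower number from compound 3 to compound 4 (0.15 log units; within the scatter), so this position accepts chloro in place of hydrogen with no shift beyond the scatter. Seen from the 3-chlorophenyl side, the same kind of change gives a 2.4-fold lower number from compound 1 to compound 4 (0.38 log units; beyond the scatter), a modest step and the only one here beyond the scatter. No measurement on hand accounts for either step.

As far as these compounds go, whether an amine or a carboxylic acid at this position still gives a number stays open. Also open is why compound 2, with the same 2,3-dichlorophenyl, gives no number.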